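Turning one double bond from Z to E

The source may hold more compounds than are shown below. What is called first, only, known or untested is meant among the compounds shown, and "the series" means these compounds.

Measured in a functional assay on HCT-116 cells (Homo sapiens) for cytotoxicity; on this read-out higher numbers stand for weaker inhibition and lower numbers for stronger inhibition:
- compound 1 `COc1cc(/C=C\c2ccc3ccccc3n2)cc(OC)c1OC`: 316 nM
- compound 2 `COc1cc(/C=C\c2cnc3ccccc3c2)cc(OC)c1OC`: 398 nM

Both measured compounds have their double bond drawn Z, one of the two possible arrangements around such a bond; the other is called E. Compound 2 gives 398 nM, which lies within the usual scatter of compound 1 at 316 nM, so the two cannot be told apart on these numbers.

The next compound is compound 3 `COc1cc(/C=C/c2cnc3ccccc3c2)cc(OC)c1OC`. The change is the two compounds have the same atoms and bonds and differ only in configuration as drawn: 1 of 1 stereo elements differ; a double bond is drawn Z in compound 2 and E in compound 3. The two compounds have the same atoms and bonds, and a double bond is drawn Z in compound 2 and E in compound 3.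

Going by the values given here, no compound with an E double bond has been measured here, so the data offer no direct guide to this step. Even so, a clear loss of inhibition seems more likely than no change, although this is a judgement and carries a wide margin. The expected step is a 7.5-fold higher number from compound 2 to compound 3 (0.88 log units; beyond the scatter), towards a higher number in this assay and beyond the scatter. Compound 3 is estimated at 3000 nM, with an expected range from 600 nM to 15000 nM.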

Compound 3, half-maximal inhibitory concentration: > 3160 nM
Compound 3: no number, only a limit; the forecaster's own chance of this, stated with the estimate: 20%; middle value at least 1.0-fold (0.02 log units) from the limit.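

Turning the double bond from Z to E gives an at least 7.9-fold higher number from compound 2 to compound 3 (0.89 log units; beyond the scatter) in this assay, the first sign in these compounds that the arrangement around this bond matters on this read-out, since the earlier pair held it fixed. The loss of inhibition can be tied to that bond alone, because nothing else in the structure changes: the fact that compounds 2 and 3 differ only in the configuration as drawn Its full size stays unknown, because the result for compound 3 is a limit and not a number: the limit of > 3160 nM in this assay, at which 1 of the 3 values shown sits.

On these data alone, this rests on a single pair, so it remains open whether the E arrangement would cost as much on the core of compound 1, where the nitrogen-containing part is attached differently. Also open, as far as these compounds go, is whether the double bond itself is needed at all, or whether an amide in its place would keep inhibition on this read-out, and how an amine in place of one methoxy group would fare in either arrangement.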